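Aryl exchange on the chain: from compound 2 to compound 3

The source may hold more compounds than are shown below. What is called first, only, known or untested is meant among the compounds shown, and "the series" means these compounds.

Two measured compounds frame this step. Going by the values given here, compound 1 `CN(C)c1ccc(/C=C(/SCc2ccc(F)cc2)C(=O)c2ccc(Cl)cc2)cc1` and compound 2 `O=C(/C(=C\c1c(O)cc(O)cc1O)SCc1ccc(Cl)cc1)c1ccc(Cl)cc1` differ from each other in two places, so no single step links their values. In a functional assay on DU-145 cells (Homo sapiens) for inhibition, read by trypan blue exclusion, with a stated time of 96 h (on this read-out higher numbers stand for weaker inhibition of growth and lower numbers for stronger inhibition of growth), compound 1 gives 50000 nM. For compound 2 this assay reports only a limit, > 100000 nM, and not a number. Compound 2 thus stands at the limit of > 100000 nM in this assay, at which 1 of the 2 values shown sits, the weaker end of what has been seen so far.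

Compound 3 `CN(C)c1ccc(/C=C(/SCc2ccc(Cl)cc2)C(=O)c2ccc(Cl)cc2)cc1` is not yet measured. It differs from compound 2 in one place: 4-(dimethylamino)phenyl in place of 2,4,6-trihydroxyphenyl on a double-bonded chain carbon bound to a double-bonded chain carbon. Among the compounds with values here, compound 1 carries the same 4-(dimethylamino)phenyl on the chain and gives 50000 nM in this assay, which is the only guide to where compound 3 may fall. The step is expected to be an at least 2.0-fold lower number from compound 2 to compound 3 (0.30 log units; that floor lies within the scatter), in the direction of stronger inhibition of growth, though with compound 2 at a limit its true size cannot be fixed. Compound 3 is therefore expected near 50000 nM, somewhere between 20000 nM and 100000 nM, with a real chance that this assay again returns only a limit.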

Compound 3, concentration for 50% growth inhibition: > 100000 nM
Compound 3 gave a limit, no number; the forecaster's own chance of this, stated with the estimate: 30%; middle value at least 2.0-fold (0.30 log units) from the limit.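

In this assay compound 3 returns only a limit, > 100000 nM, and not a number. Going by these compounds alone, with compound 2 also at a limit, the exchange of 2,4,6-trihydroxyphenyl for 4-(dimethylamino)phenyl on a double-bonded chain carbon bound to a double-bonded chain carbon cannot be read, and neither group on that carbon can be ranked against the other; the top of the range is now the common result in this small set: the limit of > 100000 nM in this assay, at which 2 of the 3 values shown sit. The one readable comparison lies elsewhere: chloro in place of fluoro on an aromatic carbon gives an at least 2.0-fold higher number from compound 1 to compound 3 (0.30 log units; that floor lies within the scatter), which points toward weaker inhibition of growth with chloro, although its size is not fixed and its floor does not establish a change beyond the scatter.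

Still open, from the compounds shown here alone, is whether bromo or trifluoromethyl in place of chloro on that aromatic carbon would continue in the same direction or return a number at all. Also open, going by these compounds, is whether a 4-carboxyphenyl or a 4-morpholinophenyl on the chain carbon would bring a value in this assay that allows the chain aryl groups to be compared.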